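Acetylating the free hydroxy of compound 2

The source may hold more compounds than are shown below. What is called first, only, known or untested is meant among the compounds shown, and "the series" means these compounds.

Measured in a functional assay on NCI/ADR-RES cells (Homo sapiens) for antiproliferative activity, read by MTT assay, with a stated time of 48 h; a lower number here means a stronger inhibitor, a higher number a weaker inhibitor
- Compound 1 `C=C1[C@H](OCC(C)C)C2=C(C[C@@](C)(OC(C)=O)[C@@H]2OC(C)=O)[C@@H](OC(=O)c2ccccc2)[C@@H](C)/C=C/C(C)(C)[C@H](OC(C)=O)[C@H](OC(C)=O)[C@H]1OCC(C)C` gives > 100000 nM (a limit)
- Compound 2 `C=C1[C@H](OC(C)=O)[C@@H](OC(C)=O)[C@@H](O)C(C)(C)/C=C/[C@H](C)[C@H](OC(=O)c2ccccc2)[C@@]2(O)C[C@@](C)(O)[C@H](OC(C)=O)[C@@H]2[C@H]1OCC(C)C` gives > 100000 nM (a limit)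

Compound 2 has only a limit and no number, as does compound 1 (the limit of > 100000 nM in this assay, at which 2 of the 2 values shown sit). Compound 3 `C=C1[C@H](OC(C)=O)[C@@H](OC(C)=O)[C@@H](OC(C)=O)C(C)(C)/C=C/[C@H](C)[C@H](OC(=O)c2ccccc2)[C@@]2(O)C[C@@](C)(O)[C@H](OC(C)=O)[C@@H]2[C@H]1OCC(C)C` differs from compound 2 by one change (acetyl in place of hydrogen on an oxygen on a saturated carbon), hydroxy to acetoxy. Within the data shown here, no measured step covers this change. In this assay no shift beyond the scatter is expected, in either direction. The expected change is a number no higher from compound 2 to compound 3 (the limit leaves the size open). Compound 3 is estimated at 100000 nM, with an expected range of 40000 nM to 200000 nM.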

Compound 3, half-maximal inhibitory concentration: > 100000 nM
Compound 3 was reported as a limit; the forecaster's own chance of this, stated with the estimate: 80%; the middle value sits exactly at the limit.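

The step from compound 2 to compound 3, hydroxy to acetoxy, cannot be read, since both compounds carry only a limit: the limit of > 100000 nM in this assay, at which 3 of the 3 values shown sit.

The compounds shown leave open whether this change affects activity at all, and which change to the shared core would give a measurable value in this assay.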